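Phenyl in place of furan-2-yl on compound 2

A few compounds are considered here, and "the series" means these few. Any claim that something is new, unique, unknown or untested is made for them only; others in the source may bear on it.

Measured so far in an ADME assay on HepG2 2.2.15 cells (Homo sapiens) for cytotoxicity, read by MTT assay; a higher number here means that more compound is tolerated, a lower number that less compound is tolerated:
- Compound 1 `C=C1CC[C@@H]2[C@](C)(COC(=O)c3ccco3)[C@H](O)CC[C@@]2(C)[C@@H]1/C=C/C1=CCOC1=O` gives 92000 nM
- Compound 2 `C=C1CC[C@@H]2[C@](C)(COC(=O)c3ccco3)[C@H](O)CC[C@@]2(C)[C@@H]1C/C=C1\C=COC1=O` gives > 2150000 nM as a limit

Compound 2 stands at the limit of > 2150000 nM in this assay, at which 1 of the 2 values shown sits, and so has no exact value. Compound 3 `C=C1CC[C@@H]2[C@](C)(COC(=O)c3ccccc3)[C@H](O)CC[C@@]2(C)[C@@H]1C/C=C1\C=COC1=O` differs from compound 2 by phenyl in place of furan-2-yl on a carbonyl carbon with phenyl in place of furan-2-yl on a carbonyl carbon. Within the data shown here, the only measured step, an at least 23-fold higher number from compound 1 to compound 2 (1.36 log units; beyond the scatter), was large, but it changed the group on a saturated ring carbon and not this one. Among the measured compounds shown here, no measured step covers the new exchange. Compound 3 keeps the group that compound 2 carries on that ring carbon, so it is expected to remain well tolerated in this assay and may meet the same limit. The estimate means an at least 1.4-fold lower number from compound 2 to compound 3 (0.15 log units; that floor lies within the scatter) as the expected step, and none beyond the scatter is foreseen. Compound 3 is estimated at 1500000 nM with an expected range from 300000 nM to 2500000 nM.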

Compound 3, half-maximal cytotoxic concentration: 82000 nM
Estimate against measurement, compound 3: 18-fold (1.26 log units) above, outside the stated range (below it).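

Compound 1 and compound 2 both carry furan-2-yl on this carbonyl carbon, so neither could show whether the group there matters in this assay. Compound 3 shows that it does: phenyl in place of furan-2-yl gives an at least 26-fold lower number from compound 2 to compound 3 (1.41 log units; beyond the scatter). This step is a floor and not an exact size, and compound 2 has only a limit: the limit of > 2150000 nM in this assay, at which 1 of the 3 values shown sits.

Only furan-2-yl and phenyl are shown on this carbonyl carbon, so it remains open whether a pyridine ring, a cyclohexyl ring or an alkyl chain there would be tolerated more like compound 2 or more like compound 3. As far as these compounds go, it is also open whether the same exchange would give a step of similar size with the group that compound 1 carries on the saturated ring carbon.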